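The source may report more compounds than this note shows. Statements on the series, on what has been measured and on what is new or still open speak of the compounds shown alone.

Working notes on the series in a functional assay on L02 cells (Homo sapiens) for inhibition, read by Griess assay, with stated times of 1 h and 24 h; on this read-out higher numbers stand for weaker inhibition and lower numbers for stronger inhibition. Compound 2 `C(=C/c1nc(Nc2ccccc2)c2sccc2n1)\c1ccccc1` stands only at a limit, > 1000000 nM. Compound 1 `CN(C)c1nc(/C=C/c2ccccc2)nc2ccsc12` is also held at a limit, > 1000000 nM. Compound 3 `Brc1cccc(Nc2nc(/C=C/c3ccccc3)nc3ccsc23)c1` likewise gives only a limit, > 1000000 nM. For the measured compounds named here, the whole record so far is the limit of > 1000000 nM in this assay, at which 3 of the 3 values shown sit, so no compound has yet given a number.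

The next change leads to compound 4 `FC(F)(F)c1ccc(Nc2nc(/C=C/c3ccccc3)nc3ccsc23)cc1`: trifluoromethyl in place of hydrogen on an aromatic carbon. Trifluoromethyl is the new group here, and it sits para to a large group.

The closest measured precedent is a step that the two limits leave unreadable from compound 2 to compound 3, which also replaces a hydrogen with a new group. Further off are a step that the two limits leave unreadable from compound 1 to compound 2 and a step that the two limits leave unreadable from compound 1 to compound 3, where the dimethylamino group is replaced. None of the three has a readable size, so they support no forecast of a real step in this assay. The expectation rests on a step that the two limits leave unreadable from compound 2 to compound 3, and none beyond the scatter is expected. If a number does appear, it can only lie on the stronger side of the limit. The expected step is a number no higher from compound 2 to compound 4 (the limit leaves the size open). For compound 4 the estimate is 1000000 nM, with an expected range from 200000 nM to 2000000 nM.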

Compound 4, half-maximal inhibitory concentration: > 1000000 nM
Compound 4 ended at the assay's limit; the forecaster's own chance of this, stated with the estimate: 75%; the middle value sits exactly at the limit.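

In this assay compound 4 gives > 1000000 nM, which is a limit and not a number. Compound 2 is held at a limit as well, and the trifluoromethyl step between compound 2 and compound 4 has no readable size. The compounds shown leave open whether any change to the series gives a measured number: the limit of > 1000000 nM in this assay, at which 4 of the 4 values shown sit.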